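Phenyl in Place of Methoxycarbonyl, Starting From a Limit

The source may report more compounds than this note shows. Statements on the series, on what has been measured and on what is new or still open speak of the compounds shown alone.

Compound 1, `Cc1c(Cc2ccc(Cl)cc2)c(=O)oc2cc(OCC(O)CN3CCC(C(N)=O)CC3)ccc12`, gives 40000 nM in an ADME assay on A549 cells (Homo sapiens) for cytotoxicity, read by CellTiter-Glo; on this read-out lower numbers stand for higher toxicity in this test and higher numbers for lower toxicity in this test.
Compound 2, `Cc1c(Cc2ccccc2C(F)(F)F)c(=O)oc2cc(OCC(O)CN3CCC(C(N)=O)CC3)ccc12`, gives > 100000 nM in this assay, which is a limit of the assay and not a number.
Compound 3, `COC(=O)c1ccc(Cc2c(C)c3ccc(OCC(O)CN4CCC(C(N)=O)CC4)cc3oc2=O)cc1`, gives > 100000 nM in this assay, again a limit of the assay rather than a number.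

Among the compounds with values here, compound 3 thus stands at the limit of > 100000 nM in this assay, at which 2 of the 3 values shown sit, and only one of the three values lies below it as a real number. Two measured steps lead into compound 3: an at least 2.5-fold higher number from compound 1 to compound 3 (0.39 log units; beyond the scatter), and a step that the two limits leave unreadable from compound 2 to compound 3. Compound 4, `Cc1c(Cc2ccc(-c3ccccc3)cc2)c(=O)oc2cc(OCC(O)CN3CCC(C(N)=O)CC3)ccc12`, differs from compound 3 by phenyl in place of methoxycarbonyl on an aromatic carbon. Within the data shown here, none of the measured steps swaps a phenyl in or out, so this change has no direct precedent among the measured compounds; the one readable step into compound 3 went upward to the limit, and the other gives no size. Compound 4 is therefore expected to remain close to the limit, with an expected step of an at least 1.4-fold lower number from compound 3 to compound 4 (0.15 log units; that floor lies within the scatter), and another limit instead of a number is about as likely as not. The estimate for compound 4 is 70000 nM, within 25000 nM to 200000 nM.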

Compound 4, half-maximal cytotoxic concentration: > 100000 nM
Compound 4 was reported as a limit; the forecaster's own chance of this, stated with the estimate: 50%; at least 1.4-fold (0.15 log units) between middle value and limit.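

Phenyl in place of chloro on this aromatic carbon gives an at least 2.5-fold higher number from compound 1 to compound 4 (0.39 log units; beyond the scatter) in this assay. Methoxycarbonyl had already given a limit at this place, and phenyl, an aromatic ring of carbon only, now does the same, so the oxygen atoms of methoxycarbonyl are not required for a compound in this series to reach the limit. The steps among compound 2, compound 3 and compound 4 cannot be read, and the assay no longer separates these compounds: the limit of > 100000 nM in this assay, at which 3 of the 4 values shown sit.

As far as these compounds go, how far compound 2, compound 3 and compound 4 lie past the limit remains unknown, so their order also stays open. From the compounds shown here alone, it is also open whether bromo, an amine or a carboxylic acid at this place would give a real number, as chloro does in compound 1.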